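This account rests on a few compounds, and the source may have more. Where it says the series, first, only, none or still open, it means among the compounds named here.

The measured compounds:
Compound 1, `C=Cc1cn([C@H]2C[C@H](O)[C@@H](CO)O2)c(=O)[nH]c1=O`, gives 14200 nM in an ADME assay on L1210/0 cells (Mus musculus) for cytotoxicity, with a stated time of 48 h; on this read-out higher numbers stand for weaker inhibition and lower numbers for stronger inhibition.
Compound 2, `CCCC#Cc1cn([C@H]2C[C@H](O)[C@@H](CO)O2)c(=O)[nH]c1=O`, gives > 200000 nM in this assay, which is a limit of the assay and not a number.
Compound 3, `O=c1[nH]c(=O)n([C@H]2C[C@H](O)[C@@H](CO)O2)cc1C#Cc1ccccc1`, gives > 200000 nM in this assay, likewise a limit and not a number.

Compound 3 therefore stands at the limit rather than at a measured value; it shares that position with compound 2, as two of the three values sit at the limit of > 200000 nM in this assay, at which 2 of the 3 values shown sit. The step under consideration leads from compound 3 to compound 4, `CC(C)(C)C#Cc1cn([C@H]2C[C@H](O)[C@@H](CO)O2)c(=O)[nH]c1=O`, through (tert-butyl in place of phenyl on a triple-bonded carbon).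

Within the data shown here, two measured steps bear on this kind of change on the shared core: an at least 14-fold higher number from compound 1 to compound 2 (1.14 log units; beyond the scatter) and an at least 14-fold higher number from compound 1 to compound 3 (1.14 log units; beyond the scatter). Both are large losses once the vinyl of compound 1 is replaced by a substituted alkyne, whether the group on the triple bond is propyl or phenyl. The step between those two alkynes, a step that the two limits leave unreadable from compound 2 to compound 3, cannot be sized, since both values are limits. Compound 4 keeps the alkyne and carries tert-butyl on it, a saturated carbon group like the propyl of compound 2, which sat at the limit.

Compound 4 is therefore expected to remain at the limit, with an estimate of 200000 nM and a range of 100000 nM to 400000 nM. The expected step is a number no higher from compound 3 to compound 4 (the limit leaves the size open), that is, no change beyond the scatter.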

Compound 4, half-maximal inhibitory concentration: > 200000 nM
Compound 4 gave a limit, no number; the forecaster's own chance of this, stated with the estimate: 80%; the middle value sits exactly at the limit.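

The third alkyne shows that the loss against the vinyl of compound 1 does not depend on one kind of group on the triple-bonded carbon: the branched tert-butyl of compound 4 gives an at least 14-fold higher number from compound 1 to compound 4 (1.14 log units; beyond the scatter). Propyl, phenyl and tert-butyl, which differ in chain, ring and branching, now all leave the read-out in this assay at the same limit, and no alkyne among the compounds shown goes against this: the limit of > 200000 nM in this assay, at which 3 of the 4 values shown sit. The steps among compound 2, compound 3 and compound 4 cannot be read, as each of them joins two limits, so the exchange of phenyl for tert-butyl has no measurable size here.

As far as these compounds go, how far these three alkynes lie past the limit stays unknown, and any order among them stays unknown with it. Also open, from the compounds shown here alone, is whether a methyl group, a hydrogen or an aminomethyl group in place of tert-butyl on a triple-bonded carbon would bring the read-out back to a number, and so whether the alkyne itself or the groups carried on it account for the loss.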